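The source may report more compounds than this note shows. Statements on the series, on what has been measured and on what is new or still open speak of the compounds shown alone.

Measured so far:
compound 1 `COc1ccc2[nH]c(-c3nc(-c4ccc(Cl)cc4)no3)cc2c1`, > 50000 nM
compound 2 `Fc1ccc2[nH]c(-c3nc(-c4ccc(Cl)cc4)no3)cc2c1`, > 50000 nM
compound 3 `O=[N+]([O-])c1ccc2[nH]c(-c3nc(-c4ccc(Cl)cc4)no3)cc2c1`, > 50000 nM

Compound 1 `COc1ccc2[nH]c(-c3nc(-c4ccc(Cl)cc4)no3)cc2c1` in a functional assay on Jurkat cells (Homo sapiens) for antiproliferative activity, read by WST assay, with a stated time of 72 h (on this read-out lower numbers stand for stronger inhibition and higher numbers for weaker inhibition), gives > 50000 nM, which is a limit of the assay, not a number. Compound 2 `Fc1ccc2[nH]c(-c3nc(-c4ccc(Cl)cc4)no3)cc2c1` in this assay gives > 50000 nM, again a limit. Compound 3 `O=[N+]([O-])c1ccc2[nH]c(-c3nc(-c4ccc(Cl)cc4)no3)cc2c1` in this assay gives > 50000 nM, a limit as well. All three values sit at the same limit (the limit of > 50000 nM in this assay, at which 3 of the 3 values shown sit), so compound 2 stands level with compound 1 and compound 3 as far as these figures can tell. The steps among them are unreadable for the same reason: a step that the two limits leave unreadable from compound 1 to compound 2, a step that the two limits leave unreadable from compound 1 to compound 3 and a step that the two limits leave unreadable from compound 2 to compound 3.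

Compound 4 `COc1ccc(-c2noc(-c3cc4cc(F)ccc4[nH]3)n2)cc1` differs from compound 2 by methoxy in place of chloro on an aromatic carbon. For the measured compounds named here, none of the measured steps touches this ring, and all of them are blocked by the limit, so no step bears on the change in a readable way. Because every value recorded sits at the limit of > 50000 nM in this assay, at which 3 of the 3 values shown sit, compound 4 is expected to be reported as a limit again, and the step from compound 2 to compound 4 is estimated at a step that the limit leaves unreadable from compound 2 to compound 4. For compound 4 the estimate in this assay is 60000 nM, with a range from 20000 nM to 200000 nM.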

Compound 4, half-maximal inhibitory concentration: > 50000 nM
Compound 4: a limit, no number; the forecaster's own chance of this, stated with the estimate: 85%; the middle value is on the limit's open side.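

The step from compound 2 to compound 4 cannot be read, as both values are limits and not numbers: the limit of > 50000 nM in this assay, at which 4 of the 4 values shown sit.

The compounds shown leave open whether any change to the shared core gives a measurable value in this assay, and how large any of these steps is.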